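A few compounds are considered here, and "the series" means these few. Any claim that something is new, unique, unknown or untested is made for them only; others in the source may bear on it.

Compound 1 `O=C(CSc1nnc(-c2ccncc2)o1)N/N=C/c1ccc(Br)cc1`: 169000 nM
Compound 2 `O=C(CSc1nnc(-c2ccncc2)o1)N/N=C/c1cc(Cl)ccc1O`: 166000 nM

In an ADME assay on NIH3T3 cells (Mus musculus) for cytotoxicity, read by MTT assay, with a stated time of 24 h (on this read-out higher numbers stand for weaker inhibition and lower numbers for stronger inhibition), compound 2 holds the lower of the two numbers, yet a 1.0-fold lower number from compound 1 to compound 2 (0.01 log units; within the scatter) falls within the scatter, so the two compounds are not separated. Compound 3 `O=C(CSc1nnc(-c2ccncc2)o1)N/N=C/c1ccc(O)c(O)c1` differs from compound 2 by 3,4-dihydroxyphenyl in place of 5-chloro-2-hydroxyphenyl on a carbon with a double bond to nitrogen. Among the compounds with values here, the only measured step bearing on this exchange is a 1.0-fold lower number from compound 1 to compound 2 (0.01 log units; within the scatter), a change of the aryl group at the same place that left the number essentially unchanged. Compound 3 is therefore expected to show no step beyond the scatter, a 1.0-fold lower number from compound 2 to compound 3 (0.02 log units; within the scatter). Compound 3 is estimated at 160000 nM, ranging from 70000 nM to 350000 nM.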

Compound 3, half-maximal inhibitory concentration: 154000 nM
For compound 3 the middle estimate is 1.0-fold (0.02 log units) above the measured one, and the stated range covers the measured number.
By their numbers in this assay, from the lowest: compounds 3, 2 and 1 (each within the scatter of the next).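

In this assay the move to 3,4-dihydroxyphenyl gives a 1.1-fold lower number from compound 2 to compound 3 (0.03 log units; within the scatter) and also a 1.1-fold lower number from compound 1 to compound 3 (0.04 log units; within the scatter) when read against the 4-bromophenyl compound. A third aryl group on this carbon, now with no chlorine or bromine, therefore still does not separate the compounds, so all three stand within the scatter of one another. Nothing available explains this flat result. The compounds shown leave open whether an amine, a carboxylic acid or a longer chain in place of the aryl group would move the number beyond the scatter.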